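The source may report more compounds than this note shows. Statements on the series, on what has been measured and on what is new or still open speak of the compounds shown alone.

Compound 1, `CC1=NC(C)=C([N+](=O)[O-])C(c2ccncc2)/C1=C(\O)OC1CCCC1`: 4250 nM
Compound 2, `COCCO/C(O)=C1\C(C)=NC(C)=C([N+](=O)[O-])C1c1ccncc1`: 37700 nM

Both numbers come from a functional assay (cardiac atrium) for agonist activity, with Cavia porcellus as the target; a lower number here means that less compound is needed, a higher number that more compound is needed for the effect. Among the measured compounds shown here, of the two, compound 2 stands highest; its nearest neighbour is compound 1, and the only measured step, an 8.9-fold higher number from compound 1 to compound 2 (0.95 log units; beyond the scatter), lies between them and is modest in size. Compound 3, `CC1=NC(C)=C([N+](=O)[O-])C(c2ccncc2)/C1=C(\O)OCC(C)C`, has not been measured. It differs from compound 2 in one place: isopropyl in place of methoxymethyl on a saturated chain carbon bound to an oxygen on an unsaturated carbon. For the measured compounds named here, this change sits at the same oxygen on an unsaturated carbon that the one measured step altered, and there the hydrocarbon group gave the lower number. Compound 3 again carries a hydrocarbon group at that oxygen, so a lower number is expected, though a step smaller than an 8.9-fold higher number from compound 1 to compound 2 (0.95 log units; beyond the scatter) is anticipated, isobutyl and cyclopentyl being different groups. Compound 3 is therefore estimated at 9000 nM in this assay, within 3000 nM to 27000 nM. The expected step is then a 4.2-fold lower number from compound 2 to compound 3 (0.62 log units; beyond the scatter).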

Compound 3, half-maximal effective concentration: 8510 nM
Compound 3: the middle estimate sits 1.1-fold (0.02 log units) above what was measured; the range from low to high includes it.
By their numbers in this assay, from the lowest: compounds 1 and 3 (each within the scatter of the next); then compound 2.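

In this assay, isopropyl in place of methoxymethyl on a saturated chain carbon bound to an oxygen on an unsaturated carbon gives a 4.4-fold lower number from compound 2 to compound 3 (0.65 log units; beyond the scatter) in a pair without any ring in the changed group. Isobutyl in place of cyclopentyl on an oxygen on an unsaturated carbon gives a 2.0-fold higher number from compound 1 to compound 3 (0.30 log units; within the scatter) and so separates neither compound from the other, which means the ring of compound 1 is not required for a number in this range. Among these three compounds, only the 2-methoxyethyl group of compound 2 stands apart, and nothing available bears on the reason.

From the compounds shown here alone, whether a longer chain such as n-hexyl would stay level with isobutyl and cyclopentyl remains open. So does whether a 2-hydroxyethyl or 2-aminoethyl group would behave like 2-methoxyethyl.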